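The source may hold more compounds than are shown below. What is called first, only, known or untested is meant among the compounds shown, and "the series" means these compounds.

In an ADME assay on MT4 cells (Homo sapiens) for cytotoxicity, read by MTT assay, with a stated time of 4 days (a lower number here means that less compound is tolerated, a higher number that more compound is tolerated), compound 1 `Cc1c(Cc2c(F)cccc2F)nc(N(C)c2ccccc2)[nH]c1=O` gives > 73000 nM, which is a limit. Compound 2 `CCN(CC)c1nc(Cc2c(F)cccc2F)c(C)c(=O)[nH]1` gives > 81000 nM, which is also a limit, so it stands with no exact number. Compound 3 `Cc1c(Cc2c(F)cccc2F)nc(N2CCCCC2C)[nH]c1=O` has 2-methylpiperidin-1-yl in place of diethylamino on an aromatic carbon. Among the compounds with values here, only one measured step bears on this change, the exchange of methyl(phenyl)amino for diethylamino, and it reads a step that the two limits leave unreadable from compound 1 to compound 2. It offers no size, so no change beyond the scatter is expected in this assay. The expected step is an at least 1.0-fold lower number from compound 2 to compound 3 (0.03 log units; that floor lies within the scatter). For compound 3 the estimate is 75000 nM, with an expected range of 35000 nM to 120000 nM.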

Compound 3, half-maximal cytotoxic concentration: 75000 nM
For compound 3 middle estimate and measured number coincide at the digits printed, and the stated range covers the measured number.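

In this assay compound 3, with 2-methylpiperidin-1-yl on the aromatic carbon between two ring nitrogen atoms, gives 75000 nM, the only exact number among the compounds shown. The exchange of diethylamino for this ring reads as an at least 1.0-fold lower number from compound 2 to compound 3 (0.03 log units; that floor lies within the scatter), so this floor shows no change beyond the scatter but does not rule one out. The steps from compound 1 cannot be read.

The compounds shown leave open how large the step from compound 2 truly is. They also leave open whether a morpholine ring or a primary amine at this place would lower the number in this assay.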